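Swapping the aryl group on a sulfonyl in a quinoline series

This account rests on a few compounds, and the source may have more. Where it says the series, first, only, none or still open, it means among the compounds named here.

Measured so far:
- compound 1, `COc1ccc(S(=O)(=O)c2cnc3ccc(C)cc3c2N2CCC(C)CC2)cc1Cl`: 93%
- compound 2, `COc1ccc2ncc(S(=O)(=O)c3ccc(C)cc3)c(N3CCC(C)CC3)c2c1`: 90%
- compound 3, `CC1CCN(c2c(S(=O)(=O)c3ccc(F)c(F)c3)cnc3cc(Cl)ccc23)CC1`: 90%

All three compounds were tested in an assay on isolated protein for displacement of a labelled ligand from metabotropic glutamate receptor 5 (Homo sapiens), with a stated time of 60 min, tested at 1 uM; a lower number here means less inhibition, a higher number more inhibition at the concentration tested (going by the name of the read-out). Compound 1 gives 93%, the highest of the three numbers, but compound 2 with 90% and compound 3 with 90% each give a number whose gap from it falls within the usual scatter of such measurements. On the numbers alone, the three compounds cannot be told apart.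

Compound 4, `Cc1cc(C)cc(S(=O)(=O)c2cnc3ccc(C)cc3c2N2CCC(C)CC2)c1`, has not yet been measured. It differs from compound 1 in one place: 3,5-dimethylphenyl in place of 3-chloro-4-methoxyphenyl on a sulfonyl sulfur. Among the compounds with values here, no measured pair in this set isolates a change of this kind, so the size of the step can only be guessed from how uniformly high the three known values are. Compound 4 is expected to give 88%, with a range from 70% to 97%. The step of a number 5 percentage points lower from compound 1 to compound 4 (within the scatter) is thus estimated to stay within the scatter, with no direction claimed.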

Compound 4, a percentage reported as inhibition, at one concentration (the size of the read-out at that concentration, not a potency): 80%
For compound 4 the middle estimate is 8 percentage points above the measured one, and the stated range covers the measured number.
By their numbers in this assay, from the lowest: compounds 4, 2, 3 and 1 (each within the scatter of the next, the first and the last beyond it).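

In this assay, putting 3,5-dimethylphenyl in place of 3-chloro-4-methoxyphenyl on the sulfonyl sulfur gives a number 13 percentage points lower from compound 1 to compound 4 (beyond the scatter). The aryl group at this position can therefore shift the read-out by more than the usual scatter, although the step is modest and compound 4 still gives 80% at the single concentration tested. Nothing available explains the drop.

The swap removes the chlorine and the methoxy group together and adds two methyl groups, so the compounds shown cannot say which of these differences matters. Also open, as far as these compounds go, is how a phenyl carrying only a chlorine or only a methoxy group on this sulfonyl sulfur would read, and how a phenyl carrying an amine or a carboxylic acid would.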